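The source may hold more compounds than are shown below. What is called first, only, known or untested is meant among the compounds shown, and "the series" means these compounds.

Compound 1 `CCCCCC(=O)Nc1cc2nc(C3CCCCC3)[nH]c2cc1N1CCCC1` was tested in an ADME assay on Vero cells (Chlorocebus sabaeus) for cytotoxicity, read by resazurin assay, with a stated time of 3 days; on this read-out lower numbers stand for stronger inhibition and higher numbers for weaker inhibition. In this assay compound 1 gives only a limit, > 100 ug/mL, so no single number places it. Compound 2 `CN(C)c1cc2[nH]c(C3CCCCC3)nc2cc1NC(=O)OCC(F)(F)F` behaves alike: in this assay compound 2 also reaches only the limit > 100 ug/mL. Compound 3 `CCCCCC(=O)Nc1cc2nc(C3CCCCC3)[nH]c2cc1N(CC)CC` has no reading in this assay, "not determined" (no result reported). Across the compounds shown, the picture is the limit of > 100 ug/mL in this assay, at which 2 of the 3 values shown sit, and no pair of measured numbers forms a step that could be read for size or direction.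

Compound 4 `O=C(CCc1ccccc1)Nc1cc2nc(C3CCCCC3)[nH]c2cc1N1CCCC1` has not yet been measured in this assay. Compared with compound 1 it carries phenyl in place of propyl on a saturated chain carbon, two bonds along the chain from a carbonyl carbon. With compound 1 sitting at a limit and no measured step between neighbours shown, there is nothing to lean on for the size of the change. The expected step of a number no higher from compound 1 to compound 4 (the limit leaves the size open) is judged to be none beyond the scatter, in no particular direction. The estimate for compound 4 in this assay is accordingly 100 ug/mL, with a range from 40 ug/mL to 200 ug/mL, and it is expected that the assay most likely again reports only a limit.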

Compound 4, half-maximal inhibitory concentration: > 100 ug/mL
Compound 4: only a limit was reported (the forecaster's own chance of this, stated with the estimate: 70%); the middle value lies on the limit itself.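

In this assay compound 4 gives > 100 ug/mL, which is a limit and not a number. Compound 1 also stands at a limit, so the step between the two cannot be read. The compounds shown leave open whether phenyl in place of propyl alters the reading at all, since the values gather at one limit: the limit of > 100 ug/mL in this assay, at which 3 of the 4 values shown sit.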